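From Aryl Alkyne to Directly Attached Phenyl

The source may hold more compounds than are shown below. What is called first, only, known or untested is meant among the compounds shown, and "the series" means these compounds.

In a functional assay on Z-138 cells (Homo sapiens) for antiproliferative activity, with a stated time of 72 h (a higher number here means a weaker inhibitor, a lower number a stronger inhibitor), compound 1 `CCCC#Cc1cc([C@@H]2O[C@H](CO)[C@@H](O)[C@H]2O)n2ncnc(N)c12` gives 20 nM, while compound 2 `Nc1ncnn2c([C@@H]3O[C@H](CO)[C@@H](O)[C@H]3O)cc(C#Cc3ccc(F)cc3)c12` gives 89000 nM, the higher of the two numbers. For the measured compounds named here, the only measured step is a 4500-fold higher number from compound 1 to compound 2 (3.65 log units; beyond the scatter), with 4-fluorophenyl in place of propyl on a triple-bonded carbon. Compound 3 `Nc1ncnn2c([C@@H]3O[C@H](CO)[C@@H](O)[C@H]3O)cc(-c3ccccc3)c12` has not yet been measured. It differs from compound 2 as follows: phenyl in place of 2-(4-fluorophenyl)ethynyl on an aromatic carbon. The measured step changed the group on the triple bond but did not remove the triple bond, so it bears on this change only indirectly. Compound 3 keeps an aromatic ring of carbon, and a return to the level of compound 1 is not expected. A moderate step is expected, toward a lower number: a 7.4-fold lower number from compound 2 to compound 3 (0.87 log units; beyond the scatter). For compound 3 the estimated value is 12000 nM, within a range of 1000 nM to 100000 nM.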

Compound 3, half-maximal inhibitory concentration: > 100000 nM
Compound 3: only a limit was reported (the forecaster's own chance of this, stated with the estimate: 30%); middle value at least 8.3-fold (0.92 log units) from the limit.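

For compound 3, only a limit of this assay is available, not a number: the limit of > 100000 nM in this assay, at which 1 of the 3 values shown sits.

Setting phenyl directly on this aromatic carbon gives an at least 1.1-fold higher number from compound 2 to compound 3 (0.05 log units; that floor lies within the scatter), so removing the triple bond brought no recovery, and whether it cost anything further cannot be read. Against the pent-1-yn-1-yl group, the step is an at least 5000-fold higher number from compound 1 to compound 3 (3.69 log units; beyond the scatter). Of the three groups shown at this position, only that chain gives a low number; the aromatic rings do not, with or without the triple bond.

The compounds shown leave open whether the triple bond or the chain counts for more, a question that a saturated pentyl chain on this carbon would address. They also leave open where an alkyne carrying a cyclopropyl ring, a longer chain or an amine would fall.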